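The source may hold more compounds than are shown below. What is called first, only, known or untested is meant among the compounds shown, and "the series" means these compounds.

Measured compounds:
- compound 1, `C=CCn1c(SCC(=O)Nc2ccc(C(C)=O)cc2)nnc1-c1ccccc1`: 48%
- compound 2, `CCn1c(SCC(=O)Nc2ccc(C(C)=O)cc2)nnc1-c1ccc(OC)c(OC)c1`: 56%
- compound 3, `CCn1c(SCC(=O)Nc2ccc(/C(C)=N/O)cc2)nnc1-c1ccccc1`: 54%

In a functional assay on the whole organism (strain albino) for inhibition, with Rattus norvegicus as the target, read by paw edema, with stated times of 30 min and 1 h, at a dose of 0.28 mmol/kg by the oral route (a higher number here means more inhibition at the dose given (going by the name of the read-out), a lower number less inhibition), compound 3 gives 54%. Its number sits among the other two, nearest to compound 2 and furthest from compound 1, but each of those gaps is within the usual scatter of repeated measurements, so the three measured compounds cannot be told apart with confidence.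

Compound 4, `CCn1c(SCC(=O)Nc2ccc(C(C)=O)cc2)nnc1-c1ccccc1`, has not yet been measured in this assay. It differs from compound 3 in a single place: a group of 3 heavy atoms (2 carbon, 1 oxygen; no ring) in place of a group of 4 heavy atoms (2 carbon, 1 nitrogen, 1 oxygen; no ring), on an aromatic carbon. The oxime of compound 3 is exchanged for an acetyl group on the same aromatic carbon; the rest of the molecule is unchanged.

Among the measured compounds shown here, no pair of measured compounds differs in only one place, so no measured step can be used as a guide. With all three measured numbers lying close together, the expectation for compound 4 is a number in the same region, and the step of a number 2 percentage points lower from compound 3 to compound 4 (within the scatter) is expected to stay within the scatter rather than go clearly in either direction. Compound 4 is therefore estimated at 52%, with a range from 40% to 64%.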

Compound 4, a percentage reported as inhibition, in the whole organism at one dose (the size of the read-out at that dose, not a potency): 50%
Compound 4: the middle estimate sits 2 percentage points above what was measured; the measured number falls inside the stated range.
By their numbers in this assay, from the lowest: compounds 1, 4, 3 and 2 (each within the scatter of the next).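

In this assay, exchanging the oxime for acetyl on the aromatic carbon para to a large group gives a number 4 percentage points lower from compound 3 to compound 4 (within the scatter) and so shows that, at this position, the acetyl without the hydrogen-bond donor of the oxime cannot be told apart from the oxime. Compound 4 also opens single-place comparisons elsewhere on the molecule: phenyl in place of 3,4-dimethoxyphenyl gives a number 6 percentage points lower from compound 2 to compound 4 (within the scatter) and methyl in place of vinyl on the saturated chain carbon bound to an aromatic nitrogen gives a number 2 percentage points higher from compound 1 to compound 4 (within the scatter) as the remaining step. None of the three changes therefore clearly shifts the inhibition of paw edema at this dose.

From the compounds shown here alone, whether an amine or a carboxylic acid on this aromatic carbon would produce a step beyond the scatter remains open. No measured property is available to explain these small steps.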